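The source may report more compounds than this note shows. Statements on the series, on what has been measured and on what is new or still open speak of the compounds shown alone.

Compound 1 `CCCCCCCCCCCOc1ccccc1CCC(=O)OC[C@H]1OCC=C[C@@H]1OP(=O)(O)OC[C@H](N)C(=O)O` in an assay on HEK293-A cells for agonist activity at putative P2Y purinoceptor 10 (Mus musculus), with a stated time of 1.5 h; a higher number here means a larger maximal response, a lower number a smaller maximal response: 7.6%
Compound 2 `N[C@@H](COP(=O)(O)O[C@@H]1C=CCO[C@@H]1COC(=O)CCc1ccccc1OCc1cccc(Oc2ccccc2)c1)C(=O)O` in this assay : "not active" (no number reported)
Compound 3 `CCCCCCCC/C=C\CCCCCCCC(=O)O[C@H]1CCCO[C@@H]1COP(=O)(O)OC[C@H](N)C(=O)O` in this assay : "not active" (no number reported)

Of the compounds shown here, three have been measured in this assay. Compound 1 gives 7.6%, a small maximal response. Compound 2 gives "not active" (no number reported), with no number reported, and compound 3 likewise gives "not active" (no number reported). Compound 2 therefore stands without a single number in this assay, together with compound 3; it is one of two such entries, and no step between any two of the measured compounds is shown.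

The account now turns from compound 2 to compound 4 `N[C@@H](COP(=O)(O)O[C@H]1C=CCO[C@@H]1COC(=O)CCc1ccccc1OCc1cccc(Oc2ccccc2)c1)C(=O)O`, which has not yet been measured in this assay. The difference between the two is confined to one stereo element: the two compounds have the same atoms and bonds; at least one stereo element is drawn with a configuration in one of them and without one in the other: 1 of 4 stereo elements differ; a stereocentre at a saturated ring carbon is drawn R in compound 2 and S in compound 4

Among the measured compounds shown here, there is no measured step to guide the size of the change in this assay, and compound 2 itself has no number. The step is expected to be small, if present at all, and no clear direction beyond the scatter can be given. Compound 4 is estimated to reach 8% in this assay, within a range from 0% to 25%.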

Compound 4, largest response reached (Emax), in percent of the reference or control that the assay uses: 11.5%
Beside the measured number, compound 4's estimate is 3.5 percentage points below it, within the range that was stated.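

Among the compounds shown here, compound 2 has no number and compound 4 gives 11.5% in this assay, so no step between them can be read. The compounds shown leave open whether the stereocentre affects the maximal response, and the comparison carries one further uncertainty: the fact that one of compounds 2 and 4 is drawn with a defined configuration and the other without, at the place where they differ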